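Sulfonyl group swap from compound 3 to compound 4

A few compounds are considered here, and "the series" means these few. Any claim that something is new, unique, unknown or untested is made for them only; others in the source may bear on it.

compound 1 `N#C/C(=C\c1ccccc1OS(=O)(=O)c1ccccc1[N+](=O)[O-])C(=O)Nc1nnc(Cc2cccc3ccccc23)s1` gives 23% in a functional assay on HL-60 cells (Homo sapiens) for inhibition, read by CCK-8 assay, with a stated time of 48 h, tested at 20 uM; on this read-out higher numbers stand for more inhibition of growth at the one concentration tested and lower numbers for less inhibition of growth
compound 2 `Cc1ccc(S(=O)(=O)Oc2ccccc2/C=C(\C#N)C(=O)Nc2nnc(Cc3ccccc3)s2)cc1` gives 16% in this assay
compound 3 `COc1ccc(S(=O)(=O)Oc2ccccc2/C=C(\C#N)C(=O)Nc2nnc(Cc3ccccc3)s2)cc1` gives 100% in this assay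

Compound 3 stands highest of the three (100%), and both other values lie beyond the scatter from it. Compound 4 `N#C/C(=C\c1ccccc1OS(=O)(=O)c1ccccc1[N+](=O)[O-])C(=O)Nc1nnc(Cc2ccccc2)s1` carries 2-nitrophenyl in place of 4-methoxyphenyl on a sulfonyl sulfur. Among the measured compounds shown here, the one measured step at this group is a number 84 percentage points higher from compound 2 to compound 3 (beyond the scatter) for methoxy in place of methyl on an aromatic carbon, so the high value of compound 3 was lost entirely in a close relative. For the measured compounds named here, no measured step isolates 2-nitrophenyl. Compound 1 does carry it, with a different group elsewhere in the structure, and compound 1 gives only 23% in this assay. A large fall is therefore expected, and the estimated step runs a number 70 percentage points lower from compound 3 to compound 4 (beyond the scatter) (not a small one, though compound 1 is only an indirect guide). The expected value for compound 4 is 30% (estimated range 10% to 70%).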

Compound 4, percent growth inhibition at one concentration: 12%
For compound 4 the middle estimate is 18 percentage points above the measured one, and the stated range covers the measured number.
By their numbers in this assay, from the lowest: compounds 4, 2 and 1 (each within the scatter of the next, the first and the last beyond it); then compound 3.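

In this assay, replacing 4-methoxyphenyl on the sulfonyl sulfur with 2-nitrophenyl gives a number 88 percentage points lower from compound 3 to compound 4 (beyond the scatter), and the comparison of the two low sulfonyl variants gives a number 4 percentage points lower from compound 2 to compound 4 (within the scatter), so 2-nitrophenyl and 4-methylphenyl cannot be told apart here and only 4-methoxyphenyl of these three gives a high reading. With 2-nitrophenyl held constant, phenyl in place of naphthalen-1-yl gives a number 11 percentage points lower from compound 1 to compound 4 (beyond the scatter), so the group at the far end of the core shifts the reading only modestly in this low range. Nothing available bears on the reason for the sulfonyl effect.

As far as these compounds go, whether the high reading needs the methoxy itself remains open; an ethoxy, hydroxy or amino group in its place would test this. Also open, from the compounds shown here alone, is how naphthalen-1-yl behaves alongside 4-methoxyphenyl.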